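Methylation of an inactive scaffold against a tyrosine phosphatase

The compounds below may be only part of what the source reports. "The series", "measured", "known", "first", "only" and "open" are said of these compounds alone.

Compound 1 `CC(=O)[C@@H]1[C@@H]2[C@H](Oc3ccc(cc3)C[C@]3(O)C[C@]4(C[C@@H](O)[C@](C)(C=O)[C@@H]2C4=O)C(=O)N3)[C@@H]2[C@@H](C)C[C@@H](C)C[C@]21C` and compound 2 `C[C@@H]1C[C@H](C)[C@H]2[C@H]3Oc4ccc(cc4)C[C@]4(O)C[C@]5(C[C@H](O)OO[C@@]6(C)[C@H]7O[C@@]7(C)[C@H]([C@H]3[C@H]6C5=O)[C@]2(C)C1)C(=O)N4` share a common core and were both tested in an assay on isolated protein for inhibition of receptor-type tyrosine-protein phosphatase F (Homo sapiens); on this read-out lower numbers stand for stronger inhibition and higher numbers for weaker inhibition. For compound 1 the assay reported only a limit, > 200000 nM. For compound 2 the assay likewise reported only a limit, > 200000 nM. Both values sit at the limit of > 200000 nM in this assay, at which 2 of the 2 values shown sit, so neither compound shows measurable inhibition.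

Compound 3 `CO[C@@]12Cc3ccc(cc3)O[C@H]3[C@@H]4[C@H]5C(=O)[C@](C[C@H](O)OO[C@@]5(C)[C@H]5O[C@@]5(C)[C@H]4[C@]4(C)C[C@H](C)C[C@H](C)[C@@H]34)(C1)C(=O)N2` differs from compound 2 by methyl in place of hydrogen on an oxygen on a saturated carbon. Among the compounds with values here, no measured step accompanies a change of this kind here. The step that the limit leaves unreadable from compound 2 to compound 3 is expected to be none beyond the scatter. Compound 3 is therefore expected to give 300000 nM, within 100000 nM to 1000000 nM.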

Compound 3, half-maximal inhibitory concentration: > 200000 nM
Compound 3: only a limit was reported; the forecaster's own chance of this, stated with the estimate: 85%; the middle value lies beyond the limit too.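

Compound 2 and compound 3 both gave only a limit, so no step can be read for the change from hydroxy to methoxy. The compounds shown leave open whether any change to the shared core brings measurable inhibition.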